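The compounds below may be only part of what the source reports. "The series", "measured", "known", "first", "only" and "open" are said of these compounds alone.

In a functional assay on HT-29 cells (Homo sapiens) for antiproliferative activity, read by MTT assay, with a stated time of 72 h (on this read-out lower numbers stand for stronger inhibition and higher numbers for weaker inhibition), compound 1, `CCCCn1ccnc1-c1cc(OC)c(OC)c(OC)c1`, gives > 100000 nM, which is a limit of the assay and not a number. Going by the values given here, compound 2, `CCCCCn1ccnc1-c1cc(OC)c(OC)c(OC)c1`, gives 60100 nM, so it holds the only true number so far and offers no wider range against which to place it. Among the compounds with values here, the one measured step is an at least 1.6-fold lower number from compound 1 to compound 2 (0.22 log units; that floor lies within the scatter), and it only lengthens the chain. Compound 3, `COc1cccc(-n2ccnc2-c2cc(OC)c(OC)c(OC)c2)c1`, makes a much larger change, with 3-methoxyphenyl in place of pentyl on an aromatic nitrogen. Within the data shown here, no measured step replaces a chain with a ring, so the size of this move in this assay is poorly defined. The weak starting value of compound 2, 60100 nM, leaves more room for a lower number than for a higher one. The expected change is a 7.5-fold lower number from compound 2 to compound 3 (0.88 log units; beyond the scatter), an estimate that carries wide uncertainty. For compound 3 the estimated value is 8000 nM, with an expected range from 500 nM to 70000 nM.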

Compound 3, half-maximal inhibitory concentration: 18900 nM
Compound 3: the middle estimate sits 2.4-fold (0.37 log units) below what was measured, within the range that was stated.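

Going by these compounds alone, on this aromatic nitrogen a ring can replace a chain and the number still falls: in this assay the change is a 3.2-fold lower number from compound 2 to compound 3 (0.50 log units; beyond the scatter), the first step in this set between two true numbers and the first to clear the scatter. The gain over the pentyl chain is modest, and compound 3 still gives 18900 nM, so the ring brings a clear but small shift rather than strong inhibition. The step of an at least 5.2-fold lower number from compound 1 to compound 3 (0.72 log units; beyond the scatter) is only a floor, because compound 1 stands at a limit and not at a number: the limit of > 100000 nM in this assay, at which 1 of the 3 values shown sits.

This step swaps a chain for a ring and brings in a methoxy group at once, so the compounds shown cannot separate those two parts of the change. On these data alone, a plain phenyl on the same nitrogen would separate them, and how a longer chain or a ring bearing an amine would behave remains open.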